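The source may report more compounds than this note shows. Statements on the series, on what has been measured and on what is new or still open speak of the compounds shown alone.

Measured compounds:
- Compound 1 `CC(C)c1n[nH]c2c(NCc3ccc(-c4ccccn4)cc3)nc(SCC(O)CN)nc12`: 55 nM
- Compound 2 `CC(C)c1n[nH]c2c(NCc3ccc(-c4ccccn4)cc3)nc(SCC3CNC(=O)O3)nc12`: 80 nM
- Compound 3 `CC(C)c1n[nH]c2c(NCc3ccc(-c4ccccn4)cc3)nc(SCC(C)(C)O)nc12`: 507 nM

In a functional assay on HT cells (Homo sapiens) for antiproliferative activity, read by fluorescence, with a stated time of 72 h (a higher number here means a weaker inhibitor of growth, a lower number a stronger inhibitor of growth), compound 3 gives the highest of the three numbers, so it is the weakest growth inhibitor of the group. The two steps leading to it, a 9.2-fold higher number from compound 1 to compound 3 (0.96 log units; beyond the scatter) and a 6.3-fold higher number from compound 2 to compound 3 (0.80 log units; beyond the scatter), both lie beyond the scatter, whereas a 1.5-fold higher number from compound 1 to compound 2 (0.16 log units; within the scatter) does not. Compound 4 `CC(C)c1n[nH]c2c(NCc3ccc(-c4ccccn4)cc3)nc(SC3CCCCC3N)nc12` is the compound still to be measured. The change is 2-aminocyclohexyl in place of 2-hydroxy-2-methylpropyl on a sulfur. The step to consider is that from compound 1, whose 2-amino-1-hydroxyethyl group carries a nitrogen, to compound 3, whose 1-hydroxy-1-methylethyl group carries none: a 9.2-fold higher number from compound 1 to compound 3 (0.96 log units; beyond the scatter). Within the data shown here, compound 4 brings a nitrogen back, within a 2-aminocyclohexyl ring, so the number is expected to move back down, though the hydroxyl of compound 1 is absent and no measured compound carries this ring, which keeps the expectation uncertain. This amounts to an expected step of a 4.6-fold lower number from compound 3 to compound 4 (0.66 log units; beyond the scatter). Compound 4 is therefore estimated at 110 nM with a range from 35 nM to 350 nM.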

Compound 4, concentration for 50% growth inhibition: 139 nM
Beside the measured number, compound 4's estimate is 1.3-fold (0.10 log units) below it; measured number inside the range.
By their numbers in this assay, from the lowest: compounds 1, 2 and 4 (each within the scatter of the next, the first and the last beyond it); then compound 3.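

In this assay the change on the sulfur gives a 3.6-fold lower number from compound 3 to compound 4 (0.56 log units; beyond the scatter) and beyond the scatter, so a 2-aminocyclohexyl group serves at this position even though it has a carbon-only ring and no hydroxyl. The comparison with the oxazolidinone-bearing compound gives a 1.7-fold higher number from compound 2 to compound 4 (0.24 log units; within the scatter) and stays within the scatter, so neither compound can be ranked above the other. By contrast, a 2.5-fold higher number from compound 1 to compound 4 (0.40 log units; beyond the scatter) lies beyond the scatter, which leaves the open-chain 3-amino-2-hydroxypropyl group with a modest edge over the ring.

A plain cyclohexyl, a 2-hydroxycyclohexyl or a simple 2-aminoethyl chain would help separate the part played by the amine from that played by the ring. Nothing available here explains the differences between these numbers.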